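Swapping the ether side chain on a trioxolane-bearing phenyl ether

The source may report more compounds than this note shows. Statements on the series, on what has been measured and on what is new or still open speak of the compounds shown alone.

The series shares a spiro-fused peroxide core carried on a phenyl ether, and two members have been measured in an ADME assay on microsomes from liver (Homo sapiens) for metabolic stability, read by LC-MS, tested at 1 uM; on this read-out higher numbers stand for fast clearance and lower numbers for slow clearance. Compound 1 `CC(C)(CN)Oc1ccc([C@H]2CC[C@]3(CC2)OOC2(O3)C3CC4CC(C3)CC2C4)cc1` gives < 7 mL.min-1.g-1 in this assay, a limit of the assay rather than a number. That value of compound 1 sits at the limit of < 7 mL.min-1.g-1 in this assay, at which 1 of the 2 values shown sits. Going by the values given here, compound 2 `OC1(COc2ccc([C@H]3CC[C@]4(CC3)OOC3(O4)C4CC5CC(C4)CC3C5)cc2)CCNCC1` gives 16 mL.min-1.g-1 in this assay, the only plain number among the values shown. Among the compounds with values here, the single measured step, an at least 2.2-fold higher number from compound 1 to compound 2 (0.35 log units; beyond the scatter), saw the 1-(aminomethyl)-1-methylethyl group replaced by (4-hydroxypiperidin-4-yl)methyl on the aryl oxygen.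

Compound 3 `N[C@H]1CC[C@H](Oc2ccc([C@H]3CC[C@]4(CC3)OOC3(O4)C4CC5CC(C4)CC3C5)cc2)CC1` has not yet been measured. Relative to compound 2 it carries 4-aminocyclohexyl in place of (4-hydroxypiperidin-4-yl)methyl on an oxygen on an aromatic ring. This change returns the side chain to a primary amine on a carbocycle, bringing it nearer to compound 1 than compound 2 is; the step from compound 1 to compound 2 was at least modest, so a move of similar size back toward slower clearance would be expected. Compound 3 is estimated at 9 mL.min-1.g-1 (range 4 mL.min-1.g-1 to 22 mL.min-1.g-1) in this assay, an expected step of a 1.8-fold lower number from compound 2 to compound 3 (0.25 log units; within the scatter).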

Compound 3, intrinsic clearance in microsomes: < 7 mL.min-1.g-1
Compound 3 was reported as a limit (the forecaster's own chance of this, stated with the estimate: 40%); middle value at least 1.2-fold (0.10 log units) from the limit.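

Putting 4-aminocyclohexyl in place of (4-hydroxypiperidin-4-yl)methyl on the oxygen on the aromatic ring gave an at least 2.2-fold lower number from compound 2 to compound 3 (0.35 log units; beyond the scatter) in this assay. Going by these compounds alone, this shows that the read-out at this position responds to more than one side chain, and that a primary amine on a carbon-only six-membered ring ends in the same place as the open-chain 1-(aminomethyl)-1-methylethyl group of compound 1, leaving compound 2 as the only member with a plain number. Compound 3, like compound 1, is reported only as a limit, and the step between those two compounds cannot be read, so neither can be placed ahead of the other: the limit of < 7 mL.min-1.g-1 in this assay, at which 2 of the 3 values shown sit.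

The change from compound 2 to compound 3 alters the ring, the hydroxyl and the link to the oxygen together, so the compounds shown do not tell which of these goes with the higher number of compound 2. On these data alone, a piperidin-4-yl group on the same oxygen, or a 4-hydroxycyclohexyl group, would each separate part of that question, and how far compound 1 and compound 3 lie past the limit also stays open.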